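Cyclopropyl Amide to 3-Chlorophenyl Amide on a Shared Core

The compounds below may be only part of what the source reports. "The series", "measured", "known", "first", "only" and "open" are said of these compounds alone.

Of the compounds shown here, two built on one core have been measured so far. Compound 1 `Cc1nccc(N2CCc3nc(C4(C(=O)Nc5ccc(F)cc5)CCC4)ccc32)n1` gives 21 nM in an assay on HeLa cells for inhibition of Indoleamine 2,3-dioxygenase 1 (Homo sapiens); on this read-out higher numbers stand for weaker inhibition and lower numbers for stronger inhibition. Compound 2 `O=C(C1CC1)N1CCc2nc(C3(C(=O)Nc4ccc(F)cc4)CCC3)ccc21` gives 8 nM in this assay. The two differ in one place, and the step reads a 2.6-fold lower number from compound 1 to compound 2 (0.42 log units; beyond the scatter). For the measured compounds named here, compound 2 thus holds the lowest of the two numbers, with compound 1 as its only neighbour.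

Compound 3 `O=C(c1cccc(Cl)c1)N1CCc2nc(C3(C(=O)Nc4ccc(F)cc4)CCC3)ccc21` awaits measurement. It departs from compound 2 in a single place: 3-chlorophenyl in place of cyclopropyl on a carbonyl carbon. Going by the values given here, no measured step bears directly on this exchange. Among the compounds with values here, the one step available, a 2.6-fold lower number from compound 1 to compound 2 (0.42 log units; beyond the scatter), changes the group on the ring nitrogen rather than the group on the carbonyl carbon, so it shows only that the region around this nitrogen tolerates a modest shift without telling which way a change on the carbonyl itself would go. The expectation for compound 3 is therefore cautious, a step of a 1.9-fold higher number from compound 2 to compound 3 (0.27 log units; within the scatter) that need not clear the scatter. Compound 3 is estimated at 15 nM, with a range from 5 nM to 50 nM.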

Compound 3, half-maximal inhibitory concentration: 3 nM
Compound 3: the middle estimate sits 5.0-fold (0.70 log units) above what was measured; measured number outside the range, below it.
By their numbers in this assay, from the lowest: compound 3; then compound 2; then compound 1.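

In this assay the earlier step changed the whole group on the ring nitrogen, whereas this exchange leaves the amide-type nitrogen and the carbonyl in place and alters only what sits on the carbonyl carbon, giving a 2.7-fold lower number from compound 2 to compound 3 (0.43 log units; beyond the scatter) and showing that this position alone can move the number beyond the scatter. The 3-chlorophenyl group, with 7 heavy atoms and a six-membered aromatic ring, replaces cyclopropyl, with 3 heavy atoms and a three-membered ring, and the number falls rather than rises, so the larger group is accepted on this carbonyl carbon in this series. Replacing 2-methylpyrimidin-4-yl with (3-chlorophenyl)carbonyl gives a 7.0-fold lower number from compound 1 to compound 3 (0.85 log units; beyond the scatter) and places compound 3 lowest of the three, with its steps to both others beyond the scatter.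

The compounds shown leave open whether the step belongs to the aromatic ring or to its chlorine, and an unsubstituted phenyl, a 4-chlorophenyl or a 3-methoxyphenyl on the same carbonyl carbon would separate these. Nothing available here explains why the number falls with this exchange.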